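Second trifluoromethyl carried from one core to another

The compounds below may be only part of what the source reports. "The series", "measured", "known", "first", "only" and "open" are said of these compounds alone.

Compound 1 `CC(O)(COc1cccc(C(F)(F)F)c1)C(=O)Nc1cccc(S(F)(F)(F)(F)F)c1` gives 31700 nM in a functional assay on DU-145 cells (Homo sapiens) for antiproliferative activity, read by propidium iodide staining, with a stated time of 96 h; on this read-out lower numbers stand for stronger inhibition and higher numbers for weaker inhibition. Compound 2 `CC(O)(COc1cc(C(F)(F)F)cc(C(F)(F)F)c1)C(=O)Nc1cccc(S(F)(F)(F)(F)F)c1` differs from compound 1 by trifluoromethyl in place of hydrogen on an aromatic carbon; in this assay compound 2 gives 9300 nM, and the step observed is a 3.4-fold lower number from compound 1 to compound 2 (0.53 log units; beyond the scatter). Compound 3 `CC(O)(CS(=O)(=O)c1cccc(C(F)(F)F)c1)C(=O)Nc1cccc(S(F)(F)(F)(F)F)c1` rests on a different core, and the difference between the two cores is not broken down here. In this assay compound 3 gives 37300 nM, a number that lies within the scatter of the number for compound 1. Within the data shown here, compound 4 `CC(O)(CS(=O)(=O)c1cc(C(F)(F)F)cc(C(F)(F)F)c1)C(=O)Nc1cccc(S(F)(F)(F)(F)F)c1` has not yet been measured; it differs from compound 3 by trifluoromethyl in place of hydrogen on an aromatic carbon, the same change as the one from compound 1 to compound 2, at the same place on the ring. Among the measured compounds shown here, only one measured pair carries this change, so the expectation for compound 4 transfers that single step with widened margins. The step expected here is a 3.1-fold lower number from compound 3 to compound 4 (0.49 log units; beyond the scatter), which rests on the measured step of a 3.4-fold lower number from compound 1 to compound 2 (0.53 log units; beyond the scatter). For compound 4 the estimate in this assay is 12000 nM, with the expected range running from 5000 nM to 30000 nM.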

Compound 4, half-maximal inhibitory concentration: 13700 nM
Compound 4: the middle estimate sits 1.1-fold (0.06 log units) below what was measured, within the range that was stated.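

In this assay, the second trifluoromethyl gives a 2.7-fold lower number from compound 3 to compound 4 (0.43 log units; beyond the scatter), so the change that lowered the number on the core of compound 1 also lowers it on the core of compound 3. The two steps do not differ in size: the same change on two cores in this assay, a 3.4-fold lower number (0.53 log units; beyond the scatter) from compound 1 to compound 2 and a 2.7-fold lower number (0.43 log units; beyond the scatter) from compound 3 to compound 4, 1.3-fold (0.10 log units) apart, within the scatter of two such steps. This shows that the step carried between these two cores, for this one change at this one place on the ring and in this one assay; it does not show that the step would carry to a third core or to another cell line, and two pairs give no explanation for it.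

The compounds shown leave open whether a different group at that place, such as a nitrile, a chlorine or an amine, would give a step of similar size on both cores. Also open, on these data alone, is whether the step would hold on a core in which a sulfide or a sulfoxide takes the place of the sulfone of compound 3.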